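The source may report more compounds than this note shows. Statements on the series, on what has been measured and on what is new or still open speak of the compounds shown alone.

Compound 1 `O=S(=O)(Cc1nc(-c2cccs2)c2sccc2n1)c1cccc(Cl)c1` belongs to a small set tested in an ADME assay on cells (Homo sapiens) for cytotoxicity, read by resazurin assay, with a stated time of 5 days; a higher number here means that more compound is tolerated, a lower number that less compound is tolerated. In this assay compound 1 gives > 50000 nM, a limit of the measurement rather than a number. Compound 2 `CCC1=C(C(=O)OCC2CCCCC2)C(c2cccc(O)c2)NC(=O)N1` in this assay gives > 10000 nM, also a limit. Compound 3 `COc1ccc(-c2nc(CSc3cccc(Cl)c3)nc3ccsc23)cn1` in this assay gives > 10000 nM, again a limit. Going by the values given here, every value shown therefore sits at the limit of > 10000 nM in this assay, at which 2 of the 3 values shown sit, or at the limit of > 50000 nM in this assay, at which 1 of the 3 values shown sits, and no two measured compounds differ in one place, so no measured step is available to calibrate the change ahead.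

Compound 4 `O=c1ccc(-c2nc(CS(=O)(=O)c3cccc(Cl)c3)nc3ccsc23)c[nH]1` has not yet been tested in this assay. It differs from compound 1 in one place: a group of 7 heavy atoms (5 carbon, 1 nitrogen, 1 oxygen; one six-membered aromatic ring with 1 hetero atom) in place of a group of 5 heavy atoms (4 carbon, 1 sulfur; one five-membered aromatic ring with 1 hetero atom), on an aromatic carbon. For the move from compound 1 to compound 4, no shift beyond the usual scatter is expected in this assay, and compound 4 is expected to sit at the limit as well. The estimated step of a number no higher from compound 1 to compound 4 (the limit leaves the size open) is expected to be essentially flat. Compound 4 is estimated at 50000 nM, within a range from 20000 nM to 100000 nM.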

Compound 4, half-maximal cytotoxic concentration: > 50000 nM
Compound 4 gave a limit, no number (the forecaster's own chance of this, stated with the estimate: 85%); the middle value lies on the limit itself.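

In this assay compound 4 gives > 50000 nM, a limit. Going by these compounds alone, compound 1 also stands at a limit, and no step between compound 1 and compound 4 can be read. The compounds shown leave open at what concentration either compound stops being tolerated, and whether replacing thiophen-2-yl changes it.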